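The source may report more compounds than this note shows. Statements on the series, on what has been measured and on what is new or still open speak of the compounds shown alone.

Measured compounds:

Compound 1, `O=C(Cc1cccnc1)c1cc2ccccc2[nH]1`, gives 65000 nM.
Compound 2, `COc1cccc2[nH]c(C(=O)Cc3cccnc3)cc12`, gives 58000 nM.
Compound 3, `O=C(Cc1cccnc1)c1cc2ccc(F)cc2[nH]1`, gives 43000 nM.

These three numbers all come from an assay on isolated protein for inhibition of Indoleamine 2,3-dioxygenase 1 (Homo sapiens), read by spectrophotometry; on this read-out higher numbers stand for weaker inhibition and lower numbers for stronger inhibition. Compound 1 has the highest of the three, but only narrowly: the nearest is compound 2, reached by a 1.1-fold lower number from compound 1 to compound 2 (0.05 log units; within the scatter), and the furthest is compound 3, reached by a 1.5-fold lower number from compound 1 to compound 3 (0.18 log units; within the scatter), and both of these steps stay inside the usual scatter of repeated measurements. Compound 4, `O=C(Cc1cccnc1)c1cc2cc(OC(F)(F)F)ccc2[nH]1`, differs from compound 1 in one place: trifluoromethoxy in place of hydrogen on an aromatic carbon. The two measured steps are the ones that bear on this change, since each of them also replaces a hydrogen on an aromatic carbon of the shared core with a small group, and neither shifted the number in this assay beyond the scatter. No step beyond the scatter is therefore expected here either. The step from compound 1 to compound 4 in this assay is expected to be a 1.3-fold lower number from compound 1 to compound 4 (0.11 log units; within the scatter). Compound 4 is estimated at 50000 nM, with a range from 20000 nM to 130000 nM.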

Compound 4, half-maximal inhibitory concentration: 13100 nM
For compound 4 the middle estimate is 3.8-fold (0.58 log units) above the measured one; measured number below the stated range.
By their numbers in this assay, from the lowest: compound 4; then compounds 3, 2 and 1 (each within the scatter of the next).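

In this assay, among the compounds shown here, the step of a 5.0-fold lower number from compound 1 to compound 4 (0.70 log units; beyond the scatter) is the first to stand beyond the scatter, though it is modest. It shows that a change on this carbon of the six-membered aromatic ring can lower the number, which neither a 1.1-fold lower number from compound 1 to compound 2 (0.05 log units; within the scatter) nor a 1.5-fold lower number from compound 1 to compound 3 (0.18 log units; within the scatter) showed. Nothing given here explains why trifluoromethoxy has this effect.

Compound 2 and compound 3 carry their groups on other carbons of the shared core, so these compounds cannot tell whether the group or the place matters more. From the compounds shown here alone, whether the gain holds for other groups on this same carbon, such as an amine, a carboxylic acid or a longer ether chain, also stays open.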